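This account rests on a few compounds, and the source may have more. Where it says the series, first, only, none or still open, it means among the compounds named here.

Measured compounds in a functional assay on WI-38 VA13 cells (Homo sapiens) for cytotoxicity; on this read-out higher numbers stand for an effect only at larger amounts of compound and lower numbers for an effect already at smaller amounts:
- compound 1, `O=C(Nc1ccc2nc(NC(=O)C3CCCCC3)sc2c1)c1ccccc1Cl`, 0.025 ug/mL
- compound 2, `O=C(Nc1ccc2nc(NC(=O)C3CCCCC3)sc2c1)c1ccccc1Oc1ccccc1`, 0.1 ug/mL
- compound 3, `O=C(Nc1ccc2nc(NC(=O)C3CCCCC3)sc2c1)c1cccc(Oc2ccccc2)c1`, > 4 ug/mL (a limit of the assay, not a number)

Compound 1 holds the lowest of the two numbers given in this assay. Its nearest neighbour is compound 2, and the step of a 4.0-fold higher number from compound 1 to compound 2 (0.60 log units; beyond the scatter) is beyond the scatter though modest. For compound 3 the assay gives only a limit, (the limit of > 4 ug/mL in this assay, at which 1 of the 3 values shown sits), so no number is known for it.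

Compound 4, `Cc1ccc(C(=O)Nc2ccc3nc(NC(=O)C4CCCCC4)sc3c2)cc1`, differs from compound 1 in one place: 4-methylphenyl in place of 2-chlorophenyl on a carbonyl carbon. For the measured compounds named here, none of the measured steps changes the same two groups, so the only guidance is indirect. The step of a 4.0-fold higher number from compound 1 to compound 2 (0.60 log units; beyond the scatter) shows that altering the substituent on this aromatic ring of compound 1 raised the number modestly, and compound 3 sits at a limit. On that basis a modest rise in this assay is expected for compound 4, in the direction of weaker effect, though a step within the scatter cannot be excluded. Compound 4 is therefore estimated at 0.1 ug/mL, with a range from 0.025 ug/mL to 0.5 ug/mL, which corresponds to the expected step of a 4.0-fold higher number from compound 1 to compound 4 (0.60 log units; beyond the scatter).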

Compound 4, half-maximal effective concentration: 5.1 ug/mL
For compound 4 the middle estimate is 51-fold (1.71 log units) below the measured one; the measured number lies above the stated range.
By their numbers in this assay, from the lowest: compound 1; then compound 2; then compound 4.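

In this assay, the swap of 2-chlorophenyl for 4-methylphenyl on the carbonyl carbon gives a 200-fold higher number from compound 1 to compound 4 (2.31 log units; beyond the scatter), a large step where the earlier change on this ring, a 4.0-fold higher number from compound 1 to compound 2 (0.60 log units; beyond the scatter), was modest. The number at this position therefore depends strongly on which aryl group the carbonyl carries, even though the two groups match in heavy-atom count and in their counted donors and acceptors. Compound 3 remains a limit of the assay and not a number, so its place relative to compound 4 cannot be read: the limit of > 4 ug/mL in this assay, at which 1 of the 4 values shown sits.

The compounds shown leave open whether the step follows the loss of chloro, the arrival of methyl or the changed place on the ring, which 4-chlorophenyl and 2-methylphenyl on the same carbonyl carbon would separate. Also open, on these data alone, is how an amine or a carboxylic acid on this ring would read.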